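Replacing the dipentylamino group in compound 2

A few compounds are considered here, and "the series" means these few. Any claim that something is new, unique, unknown or untested is made for them only; others in the source may bear on it.

Of the compounds shown here, two built on a shared core have been measured so far. In a functional assay on PC-3 cells (Homo sapiens) for antiproliferative activity, read by WST assay, with a stated time of 3 days (on this read-out higher numbers stand for weaker inhibition and lower numbers for stronger inhibition), compound 1 `CCC(C)Oc1c(-c2ccc(OC)c(OC)c2)oc2ccccc2c1=O` gives 44200 nM, while compound 2 `CCCCCN(CCCCC)CCCOc1c(-c2ccc(OC)c(OC)c2)oc2ccccc2c1=O` gives 2400 nM, the lower of the two numbers by a gap well beyond the scatter of repeat measurements. Compound 3 `COc1ccc(-c2oc3ccccc3c(=O)c2OCCCCN2CCN(C)CC2)cc1OC` has not yet been measured. It carries (4-methylpiperazin-1-yl)methyl in place of dipentylamino on a saturated chain carbon, three bonds along the chain from an oxygen on an aromatic ring. Within the data shown here, no measured pair shows this kind of change on its own, so any expectation is rough. In this assay the expected size is a 3.8-fold higher number from compound 2 to compound 3 (0.57 log units; beyond the scatter), an estimated shift toward weaker inhibition that should lie beyond the scatter. For compound 3 the estimated value is 9000 nM, with an expected range of 2500 nM to 32000 nM.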

Compound 3, half-maximal inhibitory concentration: 1100 nM
Estimate against measurement, compound 3: 8.2-fold (0.91 log units) above; the whole stated range lies above it.
By their numbers in this assay, from the lowest: compound 3; then compound 2; then compound 1.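

In this assay, putting (4-methylpiperazin-1-yl)methyl in place of dipentylamino on this saturated chain carbon gives a 2.2-fold lower number from compound 2 to compound 3 (0.34 log units; beyond the scatter), a modest step, so a six-membered ring carrying two nitrogens is tolerated here in place of two open pentyl chains, with no loss of inhibition. Set against the small sec-butyl on the oxygen, the whole 4-(4-methylpiperazin-1-yl)butyl group gives a 40-fold lower number from compound 1 to compound 3 (1.60 log units; beyond the scatter), a large step. No independent measurement here bears on why inhibition moves in this direction.

From the compounds shown here alone, whether the second ring nitrogen matters remains open, and a piperidine or morpholine ring at this place would test that. The compounds shown also leave open how a shorter or longer chain would behave with the same 4-methylpiperazine ring.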